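Bromo Added to the Core of Compound 1

A few compounds are considered here, and "the series" means these few. Any claim that something is new, unique, unknown or untested is made for them only; others in the source may bear on it.

Of the compounds shown here, three sharing a core have been measured in an assay on HeLa cells for agonist activity at Bile acid receptor (Homo sapiens), read by a luciferase reporter, with a stated time of 24 h; on this read-out lower numbers stand for smaller maximal responses and higher numbers for larger maximal responses. Compound 1 `c1ccc(-c2noc(-c3ccccc3)n2)cc1` gives 18.6%, the largest of the three numbers, yet the other two lie within the usual scatter of it. Compound 2 `COc1ccc(-c2nc(-c3cccc(C(F)(F)F)c3)no2)cc1` gives 11.4% and compound 3 `COc1ccc(-c2nc(-c3ccccc3C)no2)cc1` gives 11.4%, so no order among the three can be claimed. The new compound 4 `Brc1ccc(-c2nc(-c3ccccc3)no2)cc1` differs from compound 1 by bromo in place of hydrogen on an aromatic carbon. For the measured compounds named here, no pair of measured compounds differing in one place exists, so nothing here shows how such a change moves the response. All three known numbers sit close together. The step of a number 1.6 percentage points lower from compound 1 to compound 4 (within the scatter) is therefore expected to be small, within the scatter, with no clear direction. Compound 4 is estimated at 17%, between 8% and 30%.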

Compound 4, largest response reached (Emax), in percent of the reference or control that the assay uses: 13.4%
Compound 4: middle estimate off by 3.6 percentage points, on the high side, and the stated range covers the measured number.
By their numbers in this assay, from the lowest: compounds 2, 3, 4 and 1 (each within the scatter of the next).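

Bromo in place of hydrogen on an aromatic carbon, para to a large group, gives the first step between compounds that differ in one place: a number 5.2 percentage points lower from compound 1 to compound 4 (within the scatter), on the scale of the largest response reached. At this position, then, the swap leaves no change that can be told apart from the scatter. Nothing measured here offers a reason for this result. As far as these compounds go, whether an amine, a carboxylic acid or a longer chain on the same carbon would move the response beyond the scatter stays open.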